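This account rests on a few compounds, and the source may have more. Where it says the series, first, only, none or still open, it means among the compounds named here.

In a functional assay (aorta) with Rattus norvegicus as the target (a higher number here means a weaker inhibitor, a lower number a stronger inhibitor), compound 1 `CC1(C)Oc2ccc(C#N)cc2[C@@H](/N=C(\NC#N)Nc2ccc(Cl)cc2)[C@@H]1O` gives 1800 nM. Among the measured compounds shown here, only one other compound has been measured so far: compound 2 `COC(=O)c1cn([C@@H]2c3cc(C#N)ccc3OC(C)(C)[C@H]2O)c2ccccc12` gives 500 nM. Compound 1 therefore has the higher of the two numbers, which makes it the weaker inhibitor of the pair, and the gap lies beyond the scatter. The two compounds differ in more than one place, so this gap cannot be tied to any single structural change.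

The next compound, compound 3 `CC1(C)Oc2ccc(C#N)cc2[C@@H](/N=C(\NC#N)Nc2cccc([N+](=O)[O-])c2)[C@@H]1O`, keeps the rest of compound 1 and changes one group: 3-nitrophenyl stands in place of 4-chlorophenyl on an amine nitrogen (3-nitrophenyl in place of 4-chlorophenyl on an amine nitrogen). For the measured compounds named here, no measured pair shows what a swap of this kind does in this assay, so there is no direct precedent to lean on. With nothing pointing firmly either way, the expected step is small, slightly towards a lower number and within the scatter: a 1.4-fold lower number from compound 1 to compound 3 (0.14 log units; within the scatter). For compound 3 the estimated value is 1300 nM, with an expected range from 400 nM to 4000 nM.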

Compound 3, half-maximal inhibitory concentration: 670 nM
Compound 3: middle estimate off by 1.9-fold (0.29 log units), on the high side, within the range that was stated.
By their numbers in this assay, from the lowest: compounds 2 and 3 (each within the scatter of the next); then compound 1.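

In this assay, this step shows that the group on the amine nitrogen affects the result: a 2.7-fold lower number from compound 1 to compound 3 (0.43 log units; beyond the scatter), a modest change but one that lies beyond the usual scatter. The shared core and the six-membered aromatic ring stay in place, so the change is confined to what the ring carries, and 3-nitrophenyl brings hydrogen-bond acceptors that 4-chlorophenyl lacks. Nothing measured here explains why the number falls with this swap, and no supporting data bear on the cause.

The names 4-chlorophenyl and 3-nitrophenyl differ both in the group on the ring and in the number giving its place, so this single step cannot show which of the two matters, or whether both do. It also leaves open whether the ring needs an added group at all, which a plain phenyl could test, and whether an aromatic ring is needed here, which a cyclohexyl could test.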